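Branching an Alkoxy Chain: Expectation for Compound 3

A few compounds are considered here, and "the series" means these few. Any claim that something is new, unique, unknown or untested is made for them only; others in the source may bear on it.

Measured so far:
compound 1, `CCOc1c(-c2cc(OC)c(OC)c(OC)c2)oc2ccccc2c1=O`, 5400 nM
compound 2, `CCCCOc1c(-c2cc(OC)c(OC)c(OC)c2)oc2ccccc2c1=O`, 8900 nM

In a functional assay on LNCaP cells (Homo sapiens) for antiproliferative activity, read by WST assay, with a stated time of 3 days (on this read-out higher numbers stand for weaker inhibition and lower numbers for stronger inhibition), compound 1 holds the lower of the two numbers, yet compound 2 sits within the scatter of it, so the two cannot be told apart. Compound 3, `COc1cc(-c2oc3ccccc3c(=O)c2OC(C)C)cc(OC)c1OC`, differs from compound 1 by methyl in place of hydrogen on a saturated chain carbon bound to an oxygen on an aromatic ring and a saturated chain carbon. Among the measured compounds shown here, the one measured step, a 1.6-fold higher number from compound 1 to compound 2 (0.22 log units; within the scatter), lengthens the chain at a different point and stayed within the scatter, so for compound 3 no shift beyond the scatter is expected, with a 1.2-fold higher number from compound 1 to compound 3 (0.08 log units; within the scatter). Compound 3 is estimated at 6500 nM, within 2500 nM to 17000 nM.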

Compound 3, half-maximal inhibitory concentration: 8800 nM
Compound 3: middle estimate off by 1.4-fold (0.13 log units), on the low side, and the stated range covers the measured number.
By their numbers in this assay, from the lowest: compounds 1, 3 and 2 (each within the scatter of the next).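

Under this assay the change from ethoxy to isopropoxy gives a 1.6-fold higher number from compound 1 to compound 3 (0.21 log units; within the scatter) and so a methyl on this chain carbon, the first branch seen here, does not move the number beyond the scatter. Isopropyl in place of butyl gives a 1.0-fold lower number from compound 2 to compound 3 (0.00 log units; within the scatter) and so neither chain length nor branching has yet separated these three compounds. No evidence accompanies these numbers to explain how close they sit. Still open, on these data alone, is whether an amine, a carboxylic acid or a much longer chain in place of the isopropyl would shift the number beyond the scatter.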